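Hydroxy to nitro on the phenoxy arm of compound 2

The source may hold more compounds than are shown below. What is called first, only, known or untested is meant among the compounds shown, and "the series" means these compounds.

Measured compounds:
Compound 1, `Cc1cc(Cl)ccc1CC(C)C(=O)N1CCN(c2ccc(C(F)(F)F)cc2[C@@H](N)CC(C)C)CC1`, 38 nM
Compound 2, `CC(C)C[C@H](N)c1cc(C(F)(F)F)ccc1N1CCN(C(=O)COc2ccc(O)cc2)CC1`, 4600 nM
Compound 3, `CC(C)C[C@H](N)c1cc(C(F)(F)F)ccc1N1CCN(C(=O)CCNC2CCCCC2)CC1`, 4800 nM

In an assay on HEK293 cells for displacement of a labelled ligand from Melanocortin receptor 4 (Homo sapiens) (on this read-out higher numbers stand for weaker inhibition and lower numbers for stronger inhibition), compound 2 gives 4600 nM, the second highest of the three numbers. Its nearest neighbour is compound 3, with a gap of a 1.0-fold higher number from compound 2 to compound 3 (0.02 log units; within the scatter); the step of a 120-fold higher number from compound 1 to compound 2 (2.08 log units; beyond the scatter) separates it from compound 1, which in this assay gives 38 nM.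

Compound 4 is `CC(C)C[C@H](N)c1cc(C(F)(F)F)ccc1N1CCN(C(=O)COc2ccc([N+](=O)[O-])cc2)CC1`. It differs from compound 2 in one place: nitro in place of hydroxy on an aromatic carbon. The change sits on an aromatic carbon of a six-membered aromatic ring of carbon only, para to a large group, turning the (4-hydroxyphenoxy)methyl arm into a (4-nitrophenoxy)methyl arm.

Within the data shown here, none of the measured steps tests this exchange. Among the measured compounds shown here, the steps of a 120-fold higher number from compound 1 to compound 2 (2.08 log units; beyond the scatter) and a 130-fold higher number from compound 1 to compound 3 (2.10 log units; beyond the scatter) replace the whole arm on the carbonyl carbon, and a 1.0-fold higher number from compound 2 to compound 3 (0.02 log units; within the scatter) swaps one arm for another of a different kind; no pair shows the hydroxy itself being changed. With nothing that speaks for a shift in either direction, the expected step in this assay is no change at the digits printed from compound 2 to compound 4 (within the scatter), that is, none beyond the scatter. Compound 4 is therefore estimated at 4600 nM, in the range 1500 nM to 14000 nM.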

Compound 4, inhibition constant: 3100 nM
For compound 4 the middle estimate is 1.5-fold (0.17 log units) above the measured one, and the stated range covers the measured number.
By their numbers in this assay, from the lowest: compound 1; then compounds 4, 2 and 3 (each within the scatter of the next).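

In this assay, among these compounds, putting nitro in place of hydroxy on this aromatic carbon, para to a large group, gives a 1.5-fold lower number from compound 2 to compound 4 (0.17 log units; within the scatter) and so leaves the number unresolved from that of compound 2, which is the first direct reading of a change at this position. The (4-nitrophenoxy)methyl arm also stays level with the quite different arm of compound 3, with a 1.5-fold lower number from compound 3 to compound 4 (0.19 log units; within the scatter) as the printed step, whereas the gap to the arm of compound 1 remains wide, with an 82-fold higher number from compound 1 to compound 4 (1.91 log units; beyond the scatter) on that side, so among these compounds the exchange on the phenoxy ring does nothing to close that gap. Nothing available explains why the two groups read alike here.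

With only hydroxy and nitro shown at this carbon, it remains open whether an amine, a carboxylic acid, a methoxy group or a chlorine there would shift the number beyond the scatter. Also open, from the compounds shown here alone, is whether a longer chain in the arm on the carbonyl carbon, with either phenoxy group kept, would move these compounds any closer to compound 1.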